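Swapping the Alkyne Arm for a Nitrile on the Carbinol

The source may report more compounds than this note shows. Statements on the series, on what has been measured and on what is new or still open speak of the compounds shown alone.

Compound 1 `CC#C[C@H]1CN(S(=O)(=O)c2ccc(N)nc2)CCN1c1ccc(S(=O)(=NC)C(F)(F)F)cc1`: 266 nM
Compound 2 `C#CCC(O)(c1ccc(N2CCN(S(=O)(=O)c3ccc(N)nc3)C[C@@H]2C#CC)cc1)C(F)(F)F`: 6 nM
Compound 3 `CC#CCC(O)(c1ccc(N2CCN(S(=O)(=O)c3ccc(N)nc3)C[C@@H]2C#CC)cc1)C(F)(F)F`: 5 nM

In an assay on isolated protein for inhibition of glucokinase regulatory protein (Homo sapiens), read by AlphaScreen, with stated times of 20 min and 4 h (a higher number here means a weaker inhibitor, a lower number a stronger inhibitor), compound 3 stands at the low end of the three numbers. Its gap to compound 2 is small, a 1.2-fold lower number from compound 2 to compound 3 (0.08 log units; within the scatter), while compound 1 lies far above it, a 53-fold lower number from compound 1 to compound 3 (1.73 log units; beyond the scatter).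

Compound 4 `CC#C[C@H]1CN(S(=O)(=O)c2ccc(N)nc2)CCN1c1ccc(C(O)(CC#N)C(F)(F)F)cc1` has not been measured. It differs from compound 3 in one place: cyano in place of prop-1-yn-1-yl on a saturated chain carbon, two bonds along the chain from an aromatic carbon and an oxygen on a saturated carbon. Two kinds of step bear on this. The step of a 1.2-fold lower number from compound 2 to compound 3 (0.08 log units; within the scatter) shows that shortening the end of this same chain by one carbon changes nothing beyond the scatter. The steps of a 44-fold lower number from compound 1 to compound 2 (1.65 log units; beyond the scatter) and a 53-fold lower number from compound 1 to compound 3 (1.73 log units; beyond the scatter) show that the large gain came from installing the carbinol with its trifluoromethyl group, which compound 4 keeps. For the measured compounds named here, no measured step covers a nitrile in this position, so the change is less certain than a plain trimming. A small step is expected, a 2.0-fold higher number from compound 3 to compound 4 (0.30 log units; within the scatter). Compound 4 is estimated at 10 nM, within a range of 3 nM to 40 nM.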

Compound 4, half-maximal inhibitory concentration: 28 nM
The estimate for compound 4 lay 2.8-fold (0.45 log units) below the measured number, and the stated range covers the measured number.
By their numbers in this assay, from the lowest: compounds 3 and 2 (each within the scatter of the next); then compound 4; then compound 1.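

At this position the end of the chain turns out to matter. In this assay the swap to cyano gives a 5.6-fold higher number from compound 3 to compound 4 (0.75 log units; beyond the scatter) and a 4.7-fold higher number from compound 2 to compound 4 (0.67 log units; beyond the scatter) as well, whereas going between the two alkyne arms moved nothing beyond the scatter. So a triple bond alone does not carry the full effect, though cyanomethyl still holds part of the gain over the group in the first compound, with a 9.5-fold lower number from compound 1 to compound 4 (0.98 log units; beyond the scatter) on record for the whole change. No evidence is available on why the nitrile gives a weaker number. On these data alone, whether a longer chain ending in a nitrile, a plain ethyl group or an amine at this position would match the alkyne arms or compound 4 remains open.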